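A few compounds are considered here, and "the series" means these few. Any claim that something is new, unique, unknown or untested is made for them only; others in the source may bear on it.

Of the compounds shown here, three sharing one core have been measured in a functional assay on HCT-15 cells (Homo sapiens) for inhibition; a higher number here means a weaker inhibitor, a lower number a stronger inhibitor. Compound 1 `Oc1ccc(-c2cc(-c3ccccc3F)cc(-c3cccc(O)c3)n2)cc1` gives 5630 nM, compound 2 `Oc1ccc(-c2cc(-c3cccc(F)c3)cc(-c3cccc(O)c3)n2)cc1` gives 3070 nM, and compound 3 `Oc1ccc(-c2cc(-c3cccc(C(F)(F)F)c3)cc(-c3cccc(O)c3)n2)cc1` gives 9540 nM. Compound 3 thus has the highest of the three numbers; its distance from compound 1 is a 1.7-fold higher number from compound 1 to compound 3 (0.23 log units; within the scatter), within the scatter, whereas its distance from compound 2 is a 3.1-fold higher number from compound 2 to compound 3 (0.49 log units; beyond the scatter), beyond the scatter. Compound 4 `Oc1ccc(-c2cc(-c3ccc(C(F)(F)F)cc3)cc(-c3cccc(O)c3)n2)cc1` differs from compound 3 in one place only: 4-(trifluoromethyl)phenyl in place of 3-(trifluoromethyl)phenyl on an aromatic carbon. Going by the values given here, the single measured step that bears on shifting a substituent around the same phenyl ring is a 1.8-fold lower number from compound 1 to compound 2 (0.26 log units; within the scatter), which stayed within the scatter. Among the compounds with values here, no measured compound carries a 4-(trifluoromethyl)phenyl or any other group placed as in compound 4, so there is nothing to point to a large move in either direction. The expected step is therefore a 1.1-fold lower number from compound 3 to compound 4 (0.03 log units; within the scatter), no more than the usual scatter. The estimate for compound 4 in this assay is 9000 nM, with a range from 3500 nM to 25000 nM.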

Compound 4, half-maximal inhibitory concentration: 6440 nM
Compound 4: middle estimate off by 1.4-fold (0.15 log units), on the high side; low and high end bracket the measured number.
By their numbers in this assay, from the lowest: compounds 2, 1, 4 and 3 (each within the scatter of the next, the first and the last beyond it).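

In this assay, going by these compounds alone, the step from the 3-(trifluoromethyl)phenyl to the 4-(trifluoromethyl)phenyl group is the first test of moving this larger substituent around the phenyl ring, and the result (a 1.5-fold lower number from compound 3 to compound 4 (0.17 log units; within the scatter)) shows no difference that this assay can resolve. Within the data shown here, the new compound also cannot be told apart from the 2-fluorophenyl compound (a 1.1-fold higher number from compound 1 to compound 4 (0.06 log units; within the scatter)), but it does separate from the 3-fluorophenyl compound (a 2.1-fold higher number from compound 2 to compound 4 (0.32 log units; beyond the scatter)), a modest gap that matches the one already seen for compound 3. No supporting data are available to explain these differences.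

Going by these compounds, it remains open whether 2-(trifluoromethyl)phenyl would fall in the same narrow range. On these data alone, it is also open whether an amine or a carboxylic acid on this phenyl ring would move the number further than fluoro or trifluoromethyl have.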